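Fluoro on the benzoyl ring in a nitroaryl triazene series

The source may report more compounds than this note shows. Statements on the series, on what has been measured and on what is new or still open speak of the compounds shown alone.

Measured compounds:
compound 1 `O=C(c1ccccc1)N(/N=N/c1ccc([N+](=O)[O-])cc1Cl)c1ccc([N+](=O)[O-])cc1Cl` gives 590 nM
compound 2 `O=C(c1ccccc1F)N(/N=N/c1ccc([N+](=O)[O-])cc1Cl)c1ccc([N+](=O)[O-])cc1Cl` gives 2350 nM
compound 3 `O=C(c1ccccc1)N(/N=N/c1ccc([N+](=O)[O-])cc1C(F)(F)F)c1ccc([N+](=O)[O-])cc1C(F)(F)F` gives 600 nM

In a functional assay on HeLa cells (Homo sapiens) for cytotoxicity, read by MTT assay, with a stated time of 72 h (a lower number here means a stronger inhibitor, a higher number a weaker inhibitor), compound 1 gives 590 nM and compound 3 gives 600 nM; the two values lie within the scatter of each other. Compound 1 and compound 3 differ in more than one place, and the difference between the two cores is not broken down here. Within the core of compound 1, the change fluoro in place of hydrogen on an aromatic carbon gives a 4.0-fold higher number from compound 1 to compound 2 (0.60 log units; beyond the scatter), a modest step and beyond the scatter.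

Compound 4 `O=C(c1ccccc1F)N(/N=N/c1ccc([N+](=O)[O-])cc1C(F)(F)F)c1ccc([N+](=O)[O-])cc1C(F)(F)F` has not yet been measured in this assay. It stands to compound 3 as compound 2 stands to compound 1: fluoro in place of hydrogen on an aromatic carbon. The place is described in the same words for both pairs, so this is the same change. Going by the values given here, for compound 4 the expected step is a 4.0-fold higher number from compound 3 to compound 4 (0.60 log units; beyond the scatter), set beside the earlier one because a 4.0-fold higher number from compound 1 to compound 2 (0.60 log units; beyond the scatter) is the only measured example of this change. Compound 3 is the starting point because compound 3 gives 600 nM. Compound 4 is therefore estimated at 2400 nM, with an expected range from 1200 nM to 5000 nM.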

Compound 4, half-maximal inhibitory concentration: 800 nM
Estimate against measurement, compound 4: 3.0-fold (0.48 log units) above, and the stated range ends above it.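

In this assay, the change from phenyl to 2-fluorophenyl gives a 1.3-fold higher number from compound 3 to compound 4 (0.12 log units; within the scatter), so on this core the step stays within the scatter. The size of the step therefore did not carry from one core to the other, and the earlier step is a poor guide to the effect of this change on a new core in this series: the same change on two cores in this assay, a 4.0-fold higher number (0.60 log units; beyond the scatter) from compound 1 to compound 2 and a 1.3-fold higher number (0.12 log units; within the scatter) from compound 3 to compound 4, 3.0-fold (0.48 log units) apart, beyond the scatter of two such steps

Going by these compounds alone, the result rests on only two pairs, and the two cores differ in more than one place, so the data do not show which of those places sets the size of the step, or how the step arises.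

Still open, going by these compounds, is whether a methoxy group, an amine or a carboxylic acid on the benzoyl ring would behave alike on both cores. Also open, on these data alone, is whether a core carrying a nitrile in place of the trifluoromethyl groups would give a fluoro step like the larger or the smaller of the two.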